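The compounds below may be only part of what the source reports. "The series", "measured", "known", "first", "only" and "open" are said of these compounds alone.

Of the compounds shown here, three built on one shared core have been measured in an ADME assay on HEK293 cells for agonist activity at Toll-like receptor 8 (Homo sapiens), read by a luciferase reporter, with a stated time of 6 h; a lower number here means that less compound is needed, a higher number that more compound is needed for the effect. Compound 1 `CCCCNc1nc(N)nc2cc(OC)ccc12` gives 0.3 uM, compound 2 `CCCCNc1nc(N)nc2cc(CO)ccc12` gives 0.1 uM, and compound 3 `CCCCNc1nc(N)nc2cc(C(N)=O)ccc12` gives 2 uM. Compound 3 thus stands highest of the three numbers, so it needs the most material for the effect; compound 1 is its nearest neighbour and compound 2 the furthest. Among the measured steps, a 3.0-fold lower number from compound 1 to compound 2 (0.48 log units; beyond the scatter) is modest, whereas the two steps leading into compound 3, a 6.7-fold higher number from compound 1 to compound 3 (0.82 log units; beyond the scatter) and a 20-fold higher number from compound 2 to compound 3 (1.30 log units; beyond the scatter), both point the same way: the carbamoyl group goes with a higher number than either methoxy or hydroxymethyl.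

Compound 4 `CCCCNc1nc(N)nc2cc(CN(C)C)ccc12` has not yet been measured. It differs from compound 3 in one place, ((dimethylamino)methyl in place of carbamoyl on an aromatic carbon). The two steps into compound 3 bear directly on this change, since it removes the very carbamoyl group that carried the higher numbers, and a lower number is therefore expected, probably of similar size to those steps. Compound 4 is estimated at 0.3 uM, with a range from 0.1 uM to 1 uM. This estimate corresponds to an expected step of a 6.7-fold lower number from compound 3 to compound 4 (0.82 log units; beyond the scatter).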

Compound 4, minimum effective concentration: 0.04 uM
Beside the measured number, compound 4's estimate is 7.5-fold (0.88 log units) above it; measured number below the stated range.
By their numbers in this assay, from the lowest: compound 4; then compound 2; then compound 1; then compound 3.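

With (dimethylamino)methyl at this position, the shared core reaches the lowest number of the four, and a 50-fold lower number from compound 3 to compound 4 (1.70 log units; beyond the scatter) is the largest step seen so far, while a 7.5-fold lower number from compound 1 to compound 4 (0.88 log units; beyond the scatter) shows that it also improves on methoxy. The closest comparison keeps the saturated chain carbon on the aromatic ring and changes only the group attached to it: dimethylamino in place of hydroxy gives a 2.5-fold lower number from compound 2 to compound 4 (0.40 log units; beyond the scatter), so a low number at this position does not depend on the hydroxy group. Carbamoyl and (dimethylamino)methyl both contain nitrogen yet lie at opposite ends of the series, so the presence of nitrogen alone does not set the number.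

Nothing available explains why these groups differ. As far as these compounds go, it remains open whether a simple aminomethyl group, or a longer chain carrying the dimethylamino group, would give a lower number still.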